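Long-chain ester homologues: cytotoxicity working notes

The source may hold more compounds than are shown below. What is called first, only, known or untested is meant among the compounds shown, and "the series" means these compounds.

Measured in a functional assay on A549 cells (Homo sapiens) for cytotoxicity, read by MTT assay, with a stated time of 24 h, tested at 10 uM; on this read-out higher numbers stand for a weaker effect at the one concentration tested and lower numbers for a stronger effect:
- compound 1 `CCCCCCCCCCOC(=O)CCC(=O)N1CCN(CCCOc2cc3c(Nc4ccc(F)c(Cl)c4)ncnc3cc2OC)CC1` gives 95.7%
- compound 2 `CCCCCCCCCCCOC(=O)CCC(=O)N1CCN(CCCOc2cc3c(Nc4ccc(F)c(Cl)c4)ncnc3cc2OC)CC1` gives 93.4%
- compound 3 `CCCCCCCCCCCCCCCCCOC(=O)CCC(=O)N1CCN(CCCOc2cc3c(Nc4ccc(F)c(Cl)c4)ncnc3cc2OC)CC1` gives 95.7%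

Compound 1 and compound 2 differ by methyl in place of hydrogen on a saturated chain carbon, ten or more bonds along the chain from an oxygen next to a carbonyl group, and the measured step is a number 2.3 percentage points lower from compound 1 to compound 2 (within the scatter). Compound 3 is reached from compound 1 by heptyl in place of hydrogen on a saturated chain carbon, ten or more bonds along the chain from an oxygen next to a carbonyl group, with no change at the digits printed from compound 1 to compound 3 (within the scatter). Between compound 2 and compound 3 the step is a number 2.3 percentage points higher from compound 2 to compound 3 (within the scatter). Compound 4 `CCCCCCCCCCCCCCCCCCOC(=O)CCC(=O)N1CCN(CCCOc2cc3c(Nc4ccc(F)c(Cl)c4)ncnc3cc2OC)CC1` is the next homologue: the change from compound 3 to compound 4 is methyl in place of hydrogen on a saturated chain carbon, ten or more bonds along the chain from an oxygen next to a carbonyl group, made at a place described in exactly the same words as the change from compound 1 to compound 2, so it is the same change, occurring twice among these four compounds.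

Going by the values given here, all three numbers so far sit within the scatter of one another, and none of the chain lengths tried reached a stronger effect at the single concentration tested. The step of a number 0.7 percentage points lower from compound 3 to compound 4 (within the scatter) is expected to be small, because the same change gave a number 2.3 percentage points lower from compound 1 to compound 2 (within the scatter) from compound 1. Compound 4 is expected at 95%. For compound 4 the likely range runs from 89% to 100%.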

Compound 4, a percentage reported as activity, at one concentration (the size of the read-out at that concentration, not a potency): 94.8%
The estimate for compound 4 lay 0.2 percentage points above the measured number, within the range that was stated.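

In this assay, the methyl in place of hydrogen gives a number 0.9 percentage points lower from compound 3 to compound 4 (within the scatter), and set beside its earlier occurrence it reads: the same change on two cores in this assay, a number 2.3 percentage points lower (within the scatter) from compound 1 to compound 2 and a number 0.9 percentage points lower (within the scatter) from compound 3 to compound 4, 1.4 percentage points apart, within the scatter of two such steps. The heptyl change, seen on a second pair, gives a number 1.4 percentage points higher from compound 2 to compound 4 (within the scatter), and its comparison reads: the same change on two cores in this assay, no change at the digits printed (within the scatter) from compound 1 to compound 3 and a number 1.4 percentage points higher (within the scatter) from compound 2 to compound 4, 1.4 percentage points apart, within the scatter of two such steps. The octyl change gives a number 0.9 percentage points lower from compound 1 to compound 4 (within the scatter), so these chain extensions carry from one core to another without a detectable difference, but with every step inside the scatter this shows only that no effect of chain length can be seen across these four compounds, not that a real effect of the change transfers between cores.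

On these data alone, a stronger effect at this single concentration remains untested for any group other than these long saturated chains. Open questions are whether a shorter chain such as butyl, or an amine or a carboxylic acid at the chain end, would shift the read-out beyond the scatter.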